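This account rests on a few compounds, and the source may have more. Where it says the series, first, only, none or still open, it means among the compounds named here.

Series of amide-bearing compounds with a tertiary amine carrying two arylmethyl or arylethyl arms, examined in a toxicity assay on MDCK cells (Canis lupus familiaris) for cytotoxicity, read by crystal violet staining, with a stated time of 48 h; a lower number here means that less compound is tolerated, a higher number that more compound is tolerated. Compound 1 `Cc1ccc2[nH]c(=O)c(CN(Cc3ccc(F)cc3)Cc3ccc(-c4ccccc4)cc3)cc2c1` gives a limit in this assay, > 5000 nM. Compound 2 `Cc1ccc2[nH]c(=O)c(CN(Cc3ccc(OCCO)cc3)Cc3ccc(C(C)(C)C)cc3)cc2c1` likewise gives a limit in this assay, > 5000 nM. Compound 3 `COc1ccc([C@H](C)N(Cc2ccc(C(C)(C)C)cc2)Cc2cc3cc(C(C)C)ccc3[nH]c2=O)cc1` gives a limit in this assay as well, > 10000 nM. Going by the values given here, compound 2 thus stands at one of the two limits seen, (the limit of > 5000 nM in this assay, at which 2 of the 3 values shown sit), while compound 3 sits at the other, (the limit of > 10000 nM in this assay, at which 1 of the 3 values shown sits); none of the three returns a number, so no step between measured compounds can be read from these values.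

Compound 4 `COc1ccc(C(C)N(Cc2ccc(C(C)(C)C)cc2)Cc2cc3cc(C)ccc3[nH]c2=O)cc1Cl` is the next member, not yet measured in this assay. It differs from compound 2 in one place: 1-(3-chloro-4-methoxyphenyl)ethyl in place of 4-(2-hydroxyethoxy)benzyl on an amine nitrogen. Compound 3 also carries an arylethyl arm on the amine and gives only a limit, > 10000 nM, so a tolerance beyond the tested range is expected for compound 4 as well. The step from compound 2 to compound 4 is expected to be none beyond the scatter, a step that the limit leaves unreadable from compound 2 to compound 4, with the result most likely again a limit. Compound 4 is estimated at 8000 nM, within 3000 nM to 30000 nM.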

Compound 4, half-maximal cytotoxic concentration: > 10000 nM
Compound 4 gave a limit, no number; the forecaster's own chance of this, stated with the estimate: 70%; at least 1.2-fold (0.09 log units) between middle value and limit.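

In this assay compound 4 gives a limit, > 10000 nM. Compound 2 also gives a limit, > 5000 nM. Going by these compounds alone, with only these two limits, no step from compound 2 to compound 4 can be read. The compounds shown leave open where the half-maximal cytotoxic concentration of any of them lies, and whether this change on the amine nitrogen alters it.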